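Amide substituent variation on the piperazine-linked benzimidazole series

This account rests on a few compounds, and the source may have more. Where it says the series, first, only, none or still open, it means among the compounds named here.

Two compounds have numbers in an assay on isolated protein for inhibition of aldehyde dehydrogenase 1A1 (Homo sapiens), read by spectrophotometry, tested at 10 uM; on this read-out higher numbers stand for more inhibition at the one concentration tested (going by the name of the read-out) and lower numbers for less inhibition. Compound 1 `CCC(=O)N1CCN(Cc2nc3ccccc3n2Cc2cccc(C)c2)CC1` carries a propanoyl group on the ring nitrogen; in this assay compound 1 gives 85.1%. Among the measured compounds shown here, compound 2 `Cc1cccc(Cn2c(CN3CCN(C(=O)c4ccc(C#N)cc4)CC3)nc3ccccc32)c1` differs only at the carbonyl carbon, and in this assay compound 2 gives 20.8%, the lowest of the two numbers; the step of a number 64.3 percentage points lower from compound 1 to compound 2 (beyond the scatter) is the only measured step and it is large. Compound 3 `Cc1cccc(Cn2c(CN3CCN(C(=O)c4ccco4)CC3)nc3ccccc32)c1` has not been measured. Its change from compound 2 is furan-2-yl in place of 4-cyanophenyl on a carbonyl carbon. For the measured compounds named here, no measured step exchanges one ring-bearing carbonyl group for another, so the only guide is that the bulkier four-cyanophenyl carbonyl of compound 2 sits far below the small propanoyl of compound 1 because of a number 64.3 percentage points lower from compound 1 to compound 2 (beyond the scatter). The five-atom furan-2-yl is intermediate in size, so a moderate rise in this assay is expected: a number 21.2 percentage points higher from compound 2 to compound 3 (beyond the scatter). Compound 3 is therefore estimated at 42%, with a range from 15% to 70%, a number rather than a limit.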

Compound 3, a percentage reported as inhibition, at one concentration (the size of the read-out at that concentration, not a potency): 73.2%
For compound 3 the middle estimate is 31.2 percentage points below the measured one; the measured number lies above the stated range.
By their numbers in this assay, from the lowest: compound 2; then compound 3; then compound 1.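

In this assay the exchange at the carbonyl carbon gives a number 52.4 percentage points higher from compound 2 to compound 3 (beyond the scatter) and shows that an aromatic ring in this place is compatible with high inhibition, so the low number of compound 2 goes with 4-cyanophenyl and not with every ring here. Furan-2-yl still does not fully match ethyl, with a number 11.9 percentage points lower from compound 1 to compound 3 (beyond the scatter) as a modest step beyond the scatter. No available evidence bears on the reason for either step.

The change from 4-cyanophenyl to furan-2-yl alters the ring and removes the nitrile together, so the shown compounds cannot assign the rise to either part. Also open, from the compounds shown here alone, is where an unsubstituted phenyl, a thiophene ring or a longer alkyl chain on the carbonyl carbon would fall.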